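A few compounds are considered here, and "the series" means these few. Any claim that something is new, unique, unknown or untested is made for them only; others in the source may bear on it.

Measured compounds:
Compound 1 `N#CC1=C(N)Oc2c(N)cc3nc4ccccc4nc3c2C12C(=O)N(Cc1cnnn1-c1ccc(F)cc1)c1ccccc12` in a functional assay on MCF7 cells (Homo sapiens) for antiproliferative activity, read by MTT assay, with a stated time of 48 h (a lower number here means a stronger inhibitor, a higher number a weaker inhibitor), gives > 50000 nM, which is a limit of the assay and not a number.
Compound 2 `N#CC1=C(N)Oc2c(N)cc3nc4ccccc4nc3c2C12C(=O)N(Cc1cnnn1-c1cccc(C(F)(F)F)c1)c1ccccc12` in this assay gives 31600 nM.

Going by the values given here, compound 2 therefore stands as the only compound with a number in this assay; the one other value is a limit, (the limit of > 50000 nM in this assay, at which 1 of the 2 values shown sits). Compound 3 `CCOc1ccc(-n2nncc2CN2C(=O)C3(C(C#N)=C(N)Oc4c(N)cc5nc6ccccc6nc5c43)c3ccccc32)cc1` differs from compound 2 by 4-ethoxyphenyl in place of 3-(trifluoromethyl)phenyl on an aromatic nitrogen. Among the compounds with values here, the only measured step at this place is an at least 1.5-fold lower number from compound 1 to compound 2 (0.19 log units; that floor lies within the scatter), and since it starts from a limit it gives no firm size for what a change of the ring on the aromatic nitrogen does. The change to compound 3 again swaps one six-membered aromatic ring of carbon only for another at that nitrogen, so the measured compounds give no ground to expect a step beyond the scatter in this assay in either direction. Compound 3 is thus estimated at 30000 nM, with a range from 10000 nM to 90000 nM. The expected step from this estimate is a 1.1-fold lower number from compound 2 to compound 3 (0.02 log units; within the scatter).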

Compound 3, half-maximal inhibitory concentration: 26800 nM
Estimate against measurement, compound 3: 1.1-fold (0.05 log units) above, within the range that was stated.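

In this assay, going by these compounds alone, the step of a 1.2-fold lower number from compound 2 to compound 3 (0.07 log units; within the scatter) is the first at this position between two real numbers, and it shows that 4-ethoxyphenyl and 3-(trifluoromethyl)phenyl on the aromatic nitrogen cannot be told apart, even though the entering group brings a hydrogen-bond acceptor. The other new step, an at least 1.8-fold lower number from compound 1 to compound 3 (0.27 log units; that floor lies within the scatter), gives only a floor, so it does not show that ethoxy in place of fluoro on an aromatic carbon has a real effect. Compound 1 remains a limit of the assay and not a number: the limit of > 50000 nM in this assay, at which 1 of the 3 values shown sits.

As far as these compounds go, whether an amine or a carboxylic acid on this ring, or a chain longer than ethoxy, would move the number beyond the scatter stays open. So does whether a change elsewhere on the shared core would do so.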